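A chloro added to the anilide ring of compound 2

The source may hold more compounds than are shown below. What is called first, only, known or untested is meant among the compounds shown, and "the series" means these compounds.

Measured compounds in a functional assay on MDA-MB-231 cells (Homo sapiens) for inhibition, read by sulforhodamine B assay, with a stated time of 48 h; a lower number here means a stronger inhibitor of growth, a higher number a weaker inhibitor of growth:
compound 1, `O=C(CN1C(=O)N/C(=C\C=C\c2ccccc2)C1=O)Nc1ccc(Cl)cc1`: < 100000 nM
compound 2, `COc1ccc(/C=C2/NC(=O)N(CC(=O)Nc3cccc(C(F)(F)F)c3)C2=O)cc1`: 58900 nM

The two compounds share one core and differ in the substituent on the anilide ring and in the aryl group on the exocyclic double bond. Compound 1 `O=C(CN1C(=O)N/C(=C\C=C\c2ccccc2)C1=O)Nc1ccc(Cl)cc1` returned only a limit in this assay, < 100000 nM. Compound 2 `COc1ccc(/C=C2/NC(=O)N(CC(=O)Nc3cccc(C(F)(F)F)c3)C2=O)cc1` gave 58900 nM in this assay. Going by the values given here, of the two values, the one for compound 2 is the only number; the other is a limit (the limit of < 100000 nM in this assay, at which 1 of the 2 values shown sits). Among the compounds with values here, no step between measured compounds that differ in one place is available, so nothing yet shows how a single change moves the read-out.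

Compound 3 `COc1ccc(/C=C2/NC(=O)N(CC(=O)Nc3cc(C(F)(F)F)ccc3Cl)C2=O)cc1` is not yet measured. It differs from compound 2 by chloro in place of hydrogen on an aromatic carbon. Within the data shown here, with no measured step to guide the expectation, the change from compound 2 to compound 3 is expected to stay within the usual scatter of this assay, with a slight lean toward stronger growth inhibition. Compound 3 is therefore estimated at 40000 nM, within 15000 nM to 100000 nM. The expected step is a 1.5-fold lower number from compound 2 to compound 3 (0.17 log units; within the scatter).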

Compound 3, concentration for total growth inhibition: < 100000 nM
Compound 3 gave a limit, no number; the forecaster's own chance of this, stated with the estimate: 20%; the middle value is on the limit's open side.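

Compound 3 returned only a limit in this assay, < 100000 nM. Going by these compounds alone, the change from compound 2 to compound 3 therefore gives no step of readable size. The compounds shown leave open whether the added chloro strengthens or weakens growth inhibition, and most values offer no number to compare: the limit of < 100000 nM in this assay, at which 2 of the 3 values shown sit.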